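A Methylamino Group on Compound 3

A few compounds are considered here, and "the series" means these few. Any claim that something is new, unique, unknown or untested is made for them only; others in the source may bear on it.

Three related compounds have been tested in a functional assay (aorta) for inhibition, with Rattus norvegicus as the target; on this read-out lower numbers stand for stronger inhibition and higher numbers for weaker inhibition. Compound 1 (`Cc1nsc(-c2ccc(N3CCN(c4cccc(C(F)(F)F)c4)CC3)nc2)n1`) gives 5 nM and compound 2 (`Cc1nsc(-c2ccc(N3CCN(c4cccc(C(F)(F)F)c4)CC3)cc2)n1`) gives 10 nM, two values within the usual scatter of each other. Compound 3 (`FC(F)(F)c1cccc(N2CCN(c3ccc(-c4ncns4)nn3)CC2)c1`) gives 70 nM, the highest number of the three and beyond the scatter from both of the others.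

Compound 4 (`CNc1nsc(-c2ccc(N3CCN(c4cccc(C(F)(F)F)c4)CC3)nn2)n1`) has not been measured yet. It differs from compound 3 in one place: methylamino in place of hydrogen on an aromatic carbon. This is methylamino in place of hydrogen on an aromatic carbon of a five-membered aromatic ring with 2 nitrogen and 1 sulfur.

For the measured compounds named here, no pair of measured compounds shows this exact change, so any forecast is indirect. Going by the values given here, the only hint is that compound 1, at 5 nM, and compound 2, at 10 nM, carry a methyl group rather than hydrogen on that same ring carbon. They also differ from compound 3 elsewhere in the core, so the hint is weak. The expected change is a 3.5-fold lower number from compound 3 to compound 4 (0.54 log units; beyond the scatter), a moderate step toward stronger inhibition that is estimated to lie beyond the scatter. For compound 4 the estimate is 20 nM, with an expected range of 5 nM to 80 nM.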

Compound 4, half-maximal inhibitory concentration: 3 nM
For compound 4 the middle estimate is 6.7-fold (0.82 log units) above the measured one, and the stated range ends above it.
By their numbers in this assay, from the lowest: compounds 4, 1 and 2 (each within the scatter of the next, the first and the last beyond it); then compound 3.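

In this assay, for the compounds shown here, methylamino in place of hydrogen gives a 23-fold lower number from compound 3 to compound 4 (1.37 log units; beyond the scatter), a large step and the first change at a single place that these compounds allow to be read. It shows that this aromatic carbon, between two ring nitrogen atoms, accepts a group of 2 heavy atoms in place of hydrogen and that the read-out responds strongly to the change. Nothing measured here gives a reason for the size of this step.

On these data alone, compound 1 and compound 2 carry a methyl group on the same ring carbon but also differ from compound 3 elsewhere in the core, so the part played by the methyl group alone remains open, as does the part played by the linking nitrogen and its hydrogen. Amino, dimethylamino, ethylamino and methoxy groups on this carbon of the compound 3 core would help separate those parts, and methylamino on the cores of compound 1 and compound 2 would test whether the step carries over to them.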